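The compounds below may be only part of what the source reports. "The series", "measured", "known", "first", "only" and "open" are said of these compounds alone.

Measured in an ADME assay on L929 cells (Mus musculus) for antiproliferative activity, read by CCK-8 assay, with a stated time of 48 h; a higher number here means a weaker inhibitor, a lower number a stronger inhibitor:
compound 1 `O=c1c2ccccc2[se]n1-c1nc(SCc2ccccc2)n[nH]1` gives > 50000 nM, a limit of the assay.
compound 2 `CCCCSc1n[nH]c(-n2[se]c3ccccc3c2=O)n1` gives 30400 nM.
compound 3 `CC(C)CSc1n[nH]c(-n2[se]c3ccccc3c2=O)n1` gives 33400 nM.

Compound 3 holds the higher of the two numbers shown, with compound 2 nearest: a 1.1-fold higher number from compound 2 to compound 3 (0.04 log units; within the scatter). Compound 4 `Cc1ccccc1CSc1n[nH]c(-n2[se]c3ccccc3c2=O)n1` differs from compound 3 by 2-methylphenyl in place of isopropyl on a saturated chain carbon bound to a sulfur. The measured steps that bear on this change run in the opposite direction, from an aryl to an alkyl on that carbon: an at least 1.4-fold lower number from compound 1 to compound 3 (0.17 log units; that floor lies within the scatter) and an at least 1.6-fold lower number from compound 1 to compound 2 (0.21 log units; that floor lies within the scatter), both resting on (the limit of > 50000 nM in this assay, at which 1 of the 3 values shown sits). Returning an aryl group to that carbon is therefore expected to push the number back up, a 1.8-fold higher number from compound 3 to compound 4 (0.25 log units; within the scatter), with a real chance that only a limit is reported again. Compound 4 is estimated at 60000 nM, within a range of 25000 nM to 150000 nM.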

Compound 4, half-maximal inhibitory concentration: 15600 nM
Beside the measured number, compound 4's estimate is 3.8-fold (0.59 log units) above it; the measured number lies below the stated range.
By their numbers in this assay, from the lowest: compounds 4, 2 and 3 (each within the scatter of the next, the first and the last beyond it). At a limit, above all of these: compound 1.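

In this assay, an aryl group on a saturated chain carbon bound to a sulfur need not carry a high number: 2-methylphenyl in place of isopropyl gives a 2.1-fold lower number from compound 3 to compound 4 (0.33 log units; beyond the scatter), while in place of propyl it gives a 1.9-fold lower number from compound 2 to compound 4 (0.29 log units; within the scatter). The aryl group's own substitution also counts, with methyl in place of hydrogen on an aromatic carbon giving an at least 3.2-fold lower number from compound 1 to compound 4 (0.50 log units; beyond the scatter). Compound 1 holds only a limit, so that step is a floor: the limit of > 50000 nM in this assay, at which 1 of the 4 values shown sits.

Going by these compounds, whether a chlorine or a methoxy group in place of that methyl would move the number remains open. So does the effect of a longer chain in place of the aryl group.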